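Dimethoxy-for-trifluoromethyl swap on the amide benzoyl group

This account rests on a few compounds, and the source may have more. Where it says the series, first, only, none or still open, it means among the compounds named here.

Measured so far:
Compound 1, `COc1ccc(C(=O)Nc2cccc(-c3oc4cc(-c5ccc(F)cc5)ccc4c(=O)c3O)c2)cc1`: 21100 nM
Compound 2, `O=C(Nc1cccc(-c2oc3cc(-c4ccc(F)cc4)ccc3c(=O)c2O)c1)c1ccc(C(F)(F)F)cc1`: 33000 nM

In a functional assay on GTL 16 cells for antiproliferative activity against GTL 16 cell line (Homo sapiens), read by CCK-8 assay, with a stated time of 72 h (a higher number here means a weaker inhibitor, a lower number a stronger inhibitor), compound 2 gives 33000 nM, the highest of the two numbers; its nearest neighbour is compound 1, and the step of a 1.6-fold higher number from compound 1 to compound 2 (0.19 log units; within the scatter) lies within the scatter. Compound 3, `COc1cc(OC)cc(C(=O)Nc2cccc(-c3oc4cc(-c5ccc(F)cc5)ccc4c(=O)c3O)c2)c1`, has not been measured. It differs from compound 2 by 3,5-dimethoxyphenyl in place of 4-(trifluoromethyl)phenyl on a carbonyl carbon. For the measured compounds named here, the only measured step that bears on this change is a 1.6-fold higher number from compound 1 to compound 2 (0.19 log units; within the scatter), which exchanged a methoxy for a trifluoromethyl on the same benzoyl group and gave no difference beyond the scatter. Compound 3 brings two methoxy groups back onto that ring, so no step beyond the scatter is expected in this assay. Compound 3 is therefore expected to give 22000 nM, with a range of 8000 nM to 60000 nM, meaning an estimated step of a 1.5-fold lower number from compound 2 to compound 3 (0.18 log units; within the scatter).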

Compound 3, half-maximal inhibitory concentration: 19600 nM
Compound 3: middle estimate off by 1.1-fold (0.05 log units), on the high side, within the range that was stated.
By their numbers in this assay, from the lowest: compounds 3, 1 and 2 (each within the scatter of the next).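

In this assay, the steps of a 1.7-fold lower number from compound 2 to compound 3 (0.23 log units; within the scatter) and a 1.1-fold lower number from compound 1 to compound 3 (0.03 log units; within the scatter) both lie within the scatter, so 3,5-dimethoxyphenyl on this carbonyl carbon cannot be told apart from either 4-(trifluoromethyl)phenyl or 4-methoxyphenyl. For the compounds shown here, the earlier pair covered only a single group exchanged on this ring, whereas compound 3 extends the same result to a ring carrying two methoxy groups, and the step from compound 2 brings in two hydrogen-bond acceptors without a change beyond the scatter. No measurement is available that would account for these three compounds reading alike.

The compounds shown leave open whether an amine or a carboxylic acid on this ring, or a longer alkyl chain in place of the ring on the carbonyl carbon, would give a step beyond the scatter. They also leave open how far a change elsewhere on the shared core would move the number, as all three compounds carry that core unchanged.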